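Moving Methyls Around a Sulfonamide Aryl Ring

A few compounds are considered here, and "the series" means these few. Any claim that something is new, unique, unknown or untested is made for them only; others in the source may bear on it.

Among the measured compounds shown here, compound 2 `CCc1ccc(NS(=O)(=O)c2ccc(N3CCNC3=O)cc2)cc1` is the only compound here with a definite number: in a functional assay on MCF7 cells (Homo sapiens) for antiproliferative activity, read by sulforhodamine B assay, with a stated time of 48 h (on this read-out lower numbers stand for stronger inhibition and higher numbers for weaker inhibition), compound 2 gives 810 nM. Compound 1 `CCCCCc1ccc(NS(=O)(=O)c2ccc(N3CCNC3=O)cc2)cc1` reaches only a limit of the assay, > 1000 nM, in this assay. Compound 3 `CC(C)(C)c1ccc(NS(=O)(=O)c2ccc(N3CCNC3=O)cc2)cc1` likewise reaches only a limit, > 1000 nM. Two of the three measured values sit at the limit of > 1000 nM in this assay, at which 2 of the 3 values shown sit. Compound 4 `Cc1ccc(NS(=O)(=O)c2ccc(N3CCNC3=O)cc2)c(C)c1` has not yet been measured; it differs from compound 2 by 2,4-dimethylphenyl in place of 4-ethylphenyl on a sulfonamide nitrogen. The nearest measured steps are an at least 1.2-fold higher number from compound 2 to compound 3 (0.09 log units; that floor lies within the scatter) and an at least 1.2-fold lower number from compound 1 to compound 2 (0.09 log units; that floor lies within the scatter), both touching the same aryl group, and both are only floors that lie within the scatter. No clear direction is therefore expected. The step of a 1.1-fold higher number from compound 2 to compound 4 (0.05 log units; within the scatter) is expected to stay within the scatter. Compound 4 is estimated at 900 nM, with a range from 400 nM to 2000 nM.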

Compound 4, half-maximal inhibitory concentration: 230 nM
Compound 4: the middle estimate sits 3.9-fold (0.59 log units) above what was measured; measured number below the stated range.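

The 4-ethylphenyl and the 2,4-dimethylphenyl groups have the same eight carbons and one aromatic ring, yet exchanging them gives a 3.5-fold lower number from compound 2 to compound 4 (0.55 log units; beyond the scatter). This position on the sulfonamide nitrogen therefore responds to how those carbons are joined, not only to how many there are. The earlier steps shown here in this assay could not show this, and their sizes cannot be read, since they rest on a limit: the limit of > 1000 nM in this assay, at which 2 of the 4 values shown sit.

From the compounds shown here alone, whether one methyl alone would give the same change stays open. So does how an amine or a carboxylic acid on this aromatic ring would behave.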